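From 2-chloropyridin-3-yl to 6-chloropyridin-3-yl in compound 2

The compounds below may be only part of what the source reports. "The series", "measured", "known", "first", "only" and "open" are said of these compounds alone.

Measured in a functional assay on WM1361 cells (Homo sapiens) for antiproliferative activity, read by MTT assay, with a stated time of 48 h; a higher number here means a weaker inhibitor, a lower number a stronger inhibitor:
compound 1 `O=C(Nc1cc(-c2ccccc2)[nH]n1)c1cccnc1Cl`: 17300 nM
compound 2 `Cc1ccc(-c2cc(NC(=O)c3cccnc3Cl)n[nH]2)cc1`: 15800 nM
compound 3 `COc1ncccc1C(=O)Nc1cc(-c2ccc(C)cc2)[nH]n1`: 25800 nM

The three values stay close together, and compound 2 is not separated from its two neighbours: the series shows a 1.1-fold lower number from compound 1 to compound 2 (0.04 log units; within the scatter) and a 1.6-fold higher number from compound 2 to compound 3 (0.21 log units; within the scatter). Compound 4 `Cc1ccc(-c2cc(NC(=O)c3ccc(Cl)nc3)n[nH]2)cc1` is still to be measured in this assay. It carries 6-chloropyridin-3-yl in place of 2-chloropyridin-3-yl on a carbonyl carbon. Among the measured compounds shown here, no measured step makes this exact change, and the two steps above, the closest evidence, stay within the scatter. No step beyond the scatter is therefore expected. The expected size is a 1.1-fold higher number from compound 2 to compound 4 (0.06 log units; within the scatter). For compound 4 the estimated value is 18000 nM, with an expected range of 8000 nM to 40000 nM.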

Compound 4, half-maximal inhibitory concentration: 16700 nM
Compound 4: middle estimate off by 1.1-fold (0.03 log units), on the high side; the measured number falls inside the stated range.
By their numbers in this assay, from the lowest: compounds 2, 4, 1 and 3 (each within the scatter of the next).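

In this assay, 6-chloropyridin-3-yl in place of 2-chloropyridin-3-yl on the carbonyl carbon gives a 1.1-fold higher number from compound 2 to compound 4 (0.02 log units; within the scatter) and so leaves the number unmoved. The earlier steps shown here changed other atoms; this one keeps the same atoms, joined differently, and shows that this rearrangement of the chloropyridine at the amide carbonyl does not separate the two compounds. No measurement at hand bears on why they read alike. The compounds shown leave open whether any replacement here, such as an amine or a carboxylic acid in place of the chloro group, would step beyond the scatter.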